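This account rests on a few compounds, and the source may have more. Where it says the series, first, only, none or still open, it means among the compounds named here.

Of the compounds shown here, three sharing one core have been measured in a functional assay on Jurkat cells (Homo sapiens); a lower number here means a stronger inhibitor, a higher number a weaker inhibitor. Compound 1 `CC(C)[C@H](NC(=O)COc1cccc2ccccc12)C(=O)N[C@@H](CC(=O)O)C(=O)COc1ccccc1` gives 14000 nM, compound 2 `CC(C)[C@H](NC(=O)COc1cccc2ccccc12)C(=O)N[C@@H](CC(=O)O)C(=O)COc1ccc(F)cc1F` gives 33200 nM, and compound 3 `CC(C)[C@H](NC(=O)COc1cccc2ccccc12)C(=O)N[C@@H](CC(=O)O)C(=O)COc1c(F)cccc1F` gives 2040 nM, the lowest number of the three. Compound 4 `CC(C)[C@H](NC(=O)COc1cccc2ccccc12)C(=O)N[C@@H](CC(=O)O)C(=O)COc1c(F)ccc(F)c1F` turns the 2,6-difluorophenyl group of compound 3 into 2,3,6-trifluorophenyl, with fluoro in place of hydrogen on an aromatic carbon. The measured steps that bear on this all concern fluoro on the same ring. The data show a 6.9-fold lower number from compound 1 to compound 3 (0.84 log units; beyond the scatter), which is modest, and a 2.4-fold higher number from compound 1 to compound 2 (0.38 log units; beyond the scatter), modest and in the opposite direction, while a 16-fold lower number from compound 2 to compound 3 (1.21 log units; beyond the scatter) is large. Fluoro on this ring has thus moved the number both ways, and no measured step adds a third fluoro to the 2,6-difluorophenyl group. In this assay, within the data shown here, no step clearly beyond the scatter is therefore expected, with only a slight lean towards a lower number. For compound 4 the expected step is a 1.4-fold lower number from compound 3 to compound 4 (0.13 log units; within the scatter). Compound 4 is estimated at 1500 nM, with an expected range from 450 nM to 5000 nM.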

Compound 4, half-maximal inhibitory concentration: 1200 nM
Estimate against measurement, compound 4: 1.3-fold (0.10 log units) above; the measured number falls inside the stated range.
By their numbers in this assay, from the lowest: compounds 4 and 3 (each within the scatter of the next); then compound 1; then compound 2.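

In this assay, a third fluoro, ortho to one fluoro group and para to another, gives a 1.7-fold lower number from compound 3 to compound 4 (0.23 log units; within the scatter), so this position accepts fluoro in place of hydrogen with no step beyond the scatter. The 2,3,6-trifluorophenyl group also stands well apart from the other two rings, with a 12-fold lower number from compound 1 to compound 4 (1.07 log units; beyond the scatter) and a 28-fold lower number from compound 2 to compound 4 (1.44 log units; beyond the scatter), which shows that the large gaps seen for the 2,6-difluorophenyl group persist when this third fluoro is present. Nothing measured on these compounds accounts for this result.

The compounds shown leave open whether a larger group at this position, such as chloro, methyl or methoxy, would be accepted as fluoro is. They also leave open whether a fourth fluoro on the ring, giving 2,3,5,6-tetrafluorophenyl, would change the number.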